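A few compounds are considered here, and "the series" means these few. Any claim that something is new, unique, unknown or untested is made for them only; others in the source may bear on it.

The measured compounds:

Compound 1, `COc1ccccc1N1CCN(C(=O)CCc2c(-c3ccccc3)[nH]c3ccc(Cl)cc23)CC1`; in an assay on CHO cells for displacement of a labelled ligand from Substance-P receptor (Homo sapiens) (a lower number here means a stronger inhibitor, a higher number a weaker inhibitor), compound 1 gives 5.6 nM.
Compound 2, `COc1ccccc1N1CCN(C(=O)CCc2c(-c3ccc(Cl)cc3)[nH]c3cc(Cl)cc(Cl)c23)CC1`; in this assay compound 2 gives 570 nM.
Compound 3, `Cn1c(-c2ccc(Cl)cc2)c(CCC(=O)N2CCC(O)(Cc3ccccc3)CC2)c2cc(Cl)ccc21`; in this assay compound 3 gives 0.16 nM.

Of these three, compound 3 has the lowest number in this assay and is the strongest binder of the set. Its nearest neighbour is compound 1, whose number stands well above it, beyond the scatter; compound 2 lies furthest away, also far beyond the scatter.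

Compound 4, `Cn1c(-c2ccc(Cl)cc2)c(CCC(=O)N2CCC(O)(Cc3ccccc3)CC2)c2cc(-c3ccco3)ccc21`, has not yet been measured. It differs from compound 3 in one place: furan-2-yl in place of chloro on an aromatic carbon. Among the measured compounds shown here, no step between measured compounds covers this exchange, so its size cannot be read from the data. For the measured compounds named here, with nothing among the measured compounds pointing to this position as a sensitive one, and with the rest of compound 3 kept intact, only a modest shift is expected, most likely toward a somewhat higher number but possibly none beyond the scatter. The estimated step is a 3.1-fold higher number from compound 3 to compound 4 (0.49 log units; beyond the scatter). Compound 4 is therefore expected to give about 0.5 nM in this assay, with a range from 0.1 nM to 3 nM.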

Compound 4, half-maximal inhibitory concentration: 0.79 nM
Beside the measured number, compound 4's estimate is 1.6-fold (0.20 log units) below it, and the stated range covers the measured number.
By their numbers in this assay, from the lowest: compound 3; then compound 4; then compound 1; then compound 2.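

In this assay, the exchange of chloro for furan-2-yl gives a 4.9-fold higher number from compound 3 to compound 4 (0.69 log units; beyond the scatter), so this aromatic carbon, meta to a fused ring and para to a fused ring, is not indifferent to the change, yet the step is modest. A much larger group, with 5 heavy atoms in place of 1 and a five-membered aromatic ring where there was none, is accepted there, and compound 4 still gives 0.79 nM. The exchange also brings in a hydrogen-bond acceptor along with the ring, so this single step does not separate the two changes, and nothing shown here explains its size.

On these data alone, it remains open whether another aromatic ring at this carbon, such as phenyl or thiophen-2-yl, would behave like furan-2-yl, and whether a group of quite another kind, such as an amine or a carboxylic acid, would be accepted as well. As far as these compounds go, it is also open whether the same exchange would give a step of similar size on the core of compound 1, which carries a different amide part and no methyl group on the ring nitrogen.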